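The source may hold more compounds than are shown below. What is called first, only, known or untested is meant among the compounds shown, and "the series" means these compounds.

Measured so far:
compound 1 `O=C1N(CCCCCCOc2ccc(Br)cc2)CCN1c1ccncc1`: > 25000 nM in a functional assay on cells (Homo sapiens) for cytotoxicity; on this read-out higher numbers stand for lower toxicity in this test and lower numbers for higher toxicity in this test.
compound 2 `O=C1N(CCCCCCOc2ccc(Br)cc2)CCN1c1cccnc1`: > 25000 nM.

For compound 1 this value is a limit of the test and not a number. For compound 2 it is likewise a limit. Compound 2 therefore stands at the limit of > 25000 nM in this assay, at which 2 of the 2 values shown sit, and the step that the two limits leave unreadable from compound 1 to compound 2 cannot be read. Compound 3 `O=C1N(CCCCCCOc2ccc(Br)cc2)CCN1c1ccccc1` carries phenyl in place of pyridin-3-yl on an amide-type nitrogen in a ring. Among the compounds with values here, the single measured step bears on this change only as two limits, so no step beyond the scatter is expected. Compound 3 is estimated at 25000 nM, between 8000 nM and 60000 nM, which means an expected step of a number no higher from compound 2 to compound 3 (the limit leaves the size open).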

Compound 3, half-maximal cytotoxic concentration: > 25000 nM
Compound 3 was reported as a limit; the forecaster's own chance of this, stated with the estimate: 60%; the middle value sits exactly at the limit.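

In this assay compound 3 gives > 25000 nM, a limit and not a number, so its steps from compound 1 and from compound 2 cannot be read. The compounds shown leave open whether phenyl, pyridin-3-yl and pyridin-4-yl differ at all in this assay.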